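A few compounds are considered here, and "the series" means these few. Any claim that something is new, unique, unknown or untested is made for them only; others in the source may bear on it.

Working notes on the aminoquinoline ethers in an assay on cells with melanin-concentrating hormone receptor 1 (Homo sapiens) as the target, read by radioligand binding; on this read-out lower numbers stand for stronger inhibition and higher numbers for weaker inhibition.

Compound 1, `COCC(C)Oc1cccc2ccc(N)nc12`, gives 606 nM. Compound 3, `CC1CCC(Oc2cccc3ccc(N)nc23)C1`, gives 823 nM; it carries the highest of the two numbers shown, but the step of a 1.4-fold higher number from compound 1 to compound 3 (0.13 log units; within the scatter) lies within the scatter, so compound 1 and compound 3 are not separated. Compound 2, `CCOCCOc1cccc2ccc(N)nc12`, reaches only the assay limit and gives > 2000 nM; this is a limit, not a number (the limit of > 2000 nM in this assay, at which 1 of the 3 values shown sits). Relative to that limit the steps of an at least 3.3-fold higher number from compound 1 to compound 2 (0.51 log units; beyond the scatter) and an at least 2.4-fold lower number from compound 2 to compound 3 (0.38 log units; beyond the scatter) are both beyond the scatter, with the branched ether of compound 1 and the cyclopentyl of compound 3 on the stronger side.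

Compound 4 is `CCCC(C)Oc1cccc2ccc(N)nc12`. It differs from compound 3 in one place: 1-methylbutyl in place of 3-methylcyclopentyl on an oxygen on an aromatic ring. For the measured compounds named here, both groups are saturated carbon without an acceptor, and the only measured step between two such branched groups, from compound 1 to compound 3, stayed within the scatter; the steps beyond the scatter both involve compound 2. The step of a 1.1-fold lower number from compound 3 to compound 4 (0.04 log units; within the scatter) is therefore expected to stay within the scatter. Compound 4 is estimated at 750 nM, in the range 300 nM to 2000 nM.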

Compound 4, half-maximal inhibitory concentration: 105 nM
Beside the measured number, compound 4's estimate is 7.1-fold (0.85 log units) above it; measured number outside the range, below it.
By their numbers in this assay, from the lowest: compound 4; then compounds 1 and 3 (each within the scatter of the next). At a limit, above all of these: compound 2.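

In this assay, this place on an oxygen on an aromatic ring proves sensitive even among groups with no hydrogen-bond acceptors: the change gives a 7.8-fold lower number from compound 3 to compound 4 (0.89 log units; beyond the scatter), although 3-methylcyclopentyl and 1-methylbutyl are both saturated carbon. Ethyl in place of methoxy on a saturated chain carbon, two bonds along the chain from that oxygen, gives a 5.8-fold lower number from compound 1 to compound 4 (0.76 log units; beyond the scatter), so the two branched ethers that earlier could not be separated no longer mark the low end of the numbers. The step of an at least 19-fold lower number from compound 2 to compound 4 (1.27 log units; beyond the scatter) is read against a limit, not a number: the limit of > 2000 nM in this assay, at which 1 of the 4 values shown sits.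

The compounds shown leave open whether a longer chain than 1-methylbutyl would keep the number of compound 4. They also leave open how an amine or a carboxylic acid on that chain would read here.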